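The source may hold more compounds than are shown below. What is called first, only, known or untested is meant among the compounds shown, and "the series" means these compounds.

Of the compounds shown here, two have been measured so far. Compound 1 `CC(=O)OC[C@H]1O[C@@H](n2cc(-c3cn(Cc4ccccc4)nn3)c(=O)[nH]c2=O)C[C@@H]1OC(C)=O` and compound 2 `CC(C)(C)c1ccc(Cn2cc(-c3cn([C@H]4C[C@H](O)[C@@H](CO)O4)c(=O)[nH]c3=O)nn2)cc1` share a core that carries a benzyl-type group on one side and a sugar-like part on the other. In a functional assay on ACHN cells (Homo sapiens) for cytotoxicity, read by sulforhodamine B assay, tested at 10 uM (on this read-out higher numbers stand for more inhibition at the one concentration tested (going by the name of the read-out) and lower numbers for less inhibition), compound 1 gives 99%, and in this assay compound 2 gives 102%. These two numbers sit within the usual scatter of each other, so compound 2 stands level with compound 1 on what has been measured. The next compound is compound 3 `O=c1[nH]c(=O)n([C@H]2C[C@H](O)[C@@H](CO)O2)cc1-c1cn(Cc2ccccc2)nn1`. It differs from compound 2 in one spot: hydrogen in place of tert-butyl on an aromatic carbon. Going by the values given here, no measured pair isolates this change, but compound 1, which carries no tert-butyl group either, gives 99% in this assay. The step from compound 2 to compound 3 is therefore expected to be a number 5 percentage points lower from compound 2 to compound 3 (within the scatter), a change that stays within the scatter. Compound 3 is estimated at 97% in this assay, with a range from 82% to 105%.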

Compound 3, a percentage reported as inhibition, at one concentration (the size of the read-out at that concentration, not a potency): 98.7%
For compound 3 the middle estimate is 1.7 percentage points below the measured one; the range from low to high includes it.
By their numbers in this assay, from the lowest: compounds 3, 1 and 2 (each within the scatter of the next).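

Going by these compounds alone, replacing tert-butyl with hydrogen on this aromatic carbon, para to a large group, gives a number 3.3 percentage points lower from compound 2 to compound 3 (within the scatter) in this assay and is the first direct look at this single change. Going from 4-(tert-butyl)phenyl to phenyl therefore leaves the read-out level, so at this one concentration the tert-butyl group is not needed for the inhibition seen. The read-out comes from a single concentration, so this level result describes only the size of the effect of compound 2 and compound 3 at that concentration.

As far as these compounds go, whether another group at this spot, such as an amine, a carboxylic acid or a longer alkyl chain, would shift the number remains open, as does how compound 2 and compound 3 compare at lower concentrations. Nothing shown here gives a reason for the level result.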